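The compounds below may be only part of what the source reports. "The series", "measured", "known", "first", "only" and "open" are said of these compounds alone.

Measured so far:
- compound 1 `COc1cnc(O[C@@H]2C[C@H]3C(=O)N[C@]4(C(=O)NS(=O)(=O)C5CC5)C[C@H]4/C=C\CCCC[C@@H](C)[C@H](NC(=O)OC(C)(C)C(F)(F)F)C(=O)N3C2)c2cc(Cl)ccc12`: 0.505 h
- compound 2 `CC[C@@H]1CCCC/C=C\[C@@H]2C[C@@]2(C(=O)NS(=O)(=O)C2CC2)NC(=O)[C@@H]2C[C@@H](Oc3ncc(OC)c4ccc(Cl)cc34)CN2C(=O)[C@H]1NC(=O)OC(C)(C)C(F)(F)F`: 0.8 h

In an ADME assay on microsomes from liver (Homo sapiens) for metabolic stability, read by LC-MS, using NADPH, with a stated time of 45 min (on this read-out higher numbers stand for a longer-lived compound and lower numbers for a shorter-lived compound), compound 1 gives 0.505 h and compound 2 gives 0.8 h. For the measured compounds named here, these are the only two numbers, so the standing of compound 1 rests on one comparison: a 1.6-fold higher number from compound 1 to compound 2 (0.20 log units; within the scatter). That step is methyl in place of hydrogen on a saturated chain carbon bound to a saturated ring carbon.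

The next compound is compound 3 `COc1cnc(O[C@@H]2C[C@H]3C(=O)N[C@]4(C(=O)NS(=O)(=O)C5CC5)C[C@H]4/C=C\CCCC[C@@H](C)[C@H](NC(=O)OC(C)(C)C(F)(F)F)C(=O)N3C2)c2ccccc12`, which keeps the shared core of compound 1 and differs from it as follows: hydrogen in place of chloro on an aromatic carbon. In short, this is hydrogen in place of chloro on an aromatic carbon.

Going by the values given here, the one measured step lies at a different place in the structure, and no measured pair covers a change at this aromatic carbon. The data therefore give no direction for this change, and no step beyond the scatter is expected in this assay. The expected step is a 1.0-fold lower number from compound 1 to compound 3 (0.00 log units; within the scatter). For compound 3 the expected half-life is 0.5 h. Among the compounds with values here, the estimated range for compound 3 runs from 0.25 h to 1 h, kept wide since no measured step bears directly on the change.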

Compound 3, half-life: 0.31 h
Estimate against measurement, compound 3: 1.6-fold (0.21 log units) above, within the range that was stated.
By their numbers in this assay, from the lowest: compounds 3, 1 and 2 (each within the scatter of the next, the first and the last beyond it).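

In this assay, hydrogen in place of chloro on this aromatic carbon gives a 1.6-fold lower number from compound 1 to compound 3 (0.21 log units; within the scatter), the first reading at this position; the step lies within the scatter, so the chloro is not shown to matter for half-life in this series. Together with a 1.6-fold higher number from compound 1 to compound 2 (0.20 log units; within the scatter), which lies at a different place in the structure, this makes two single-place steps, both within the scatter, and neither place is yet shown to shift the read-out. Nothing available speaks to a cause for the step at this aromatic carbon.

Only chloro and hydrogen are shown at this position, so it remains open whether a different group there, such as fluoro, a methoxy group or a nitrile, would give a step beyond the scatter. Going by these compounds, it also remains open whether hydrogen in place of chloro would read the same way on the core of compound 2, where the methyl step has already been applied to the saturated chain carbon.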